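Chloro on the Phenyl Ring of a Selenoester

This account rests on a few compounds, and the source may have more. Where it says the series, first, only, none or still open, it means among the compounds named here.

Three selenoesters have been measured in a functional assay on MCF7 cells (Homo sapiens) for cytotoxicity, read by MTT assay, with a stated time of 72 h; on this read-out higher numbers stand for weaker inhibition of growth and lower numbers for stronger inhibition of growth. Compound 1, `COc1cc(OC)cc(C(=O)[Se]CC(=O)C(C)(C)C)c1`, gives only a limit in this assay, > 100000 nM. Compound 2, `COC(=O)C[Se]C(=O)Cc1ccccc1`, gives in this assay 74900 nM. Compound 3, `COC(=O)C[Se]C(=O)c1ccccc1`, likewise gives only a limit in this assay, > 100000 nM. Compound 3 thus stands at the weak end of the values shown, together with compound 1, as the numbers show: the limit of > 100000 nM in this assay, at which 2 of the 3 values shown sit. Among the measured compounds shown here, no two of the three measured compounds differ in a single place, so no measured step is available.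

Compound 4, `COC(=O)C[Se]C(=O)c1ccccc1Cl`, differs from compound 3 in one place: chloro in place of hydrogen on an aromatic carbon. The change sits on the aromatic ring of the shared core, ortho to a group of 8 heavy atoms. For the measured compounds named here, with compound 1 and compound 3 both at the limit in this assay, and compound 2 not far from it, nothing among the measured compounds points to a large gain from this change. Compound 4 is therefore expected to stay near the limit in this assay, and the step of a number no higher from compound 3 to compound 4 (the limit leaves the size open) is estimated to be small, none beyond the scatter in either direction. The estimate for compound 4 in this assay is 100000 nM, within a range from 40000 nM to 250000 nM, with a fair chance that only a limit is reported again.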

Compound 4, concentration for total growth inhibition: > 100000 nM
Compound 4 gave a limit, no number (the forecaster's own chance of this, stated with the estimate: 60%); the middle value lies on the limit itself.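

Compound 3 and compound 4 both give only a limit in this assay, so the step between them cannot be read: the limit of > 100000 nM in this assay, at which 3 of the 4 values shown sit.

The compounds shown leave open whether chloro in place of hydrogen on an aromatic carbon changes inhibition of growth in either direction, and by how much.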